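The compounds below may be only part of what the source reports. "The series", "measured", "known", "first", "only" and "open" are said of these compounds alone.

Compound 1 `CN(C(=O)CNC(=O)c1ccccc1)c1ccc(Cl)cc1C(=O)c1ccccc1Cl`: 2.9 mg/kg
Compound 2 `CC(C)C(=O)NCC(=O)N(C)c1ccc(Cl)cc1C(=O)c1ccccc1Cl`: 6 mg/kg

For the measured compounds named here, in a functional assay on the whole organism for antagonist activity, with Mus musculus as the target (a higher number here means that more compound is needed for the effect, a lower number that less compound is needed), compound 2 gives 6 mg/kg, the higher of the two numbers measured so far, so more of it is needed for the effect than of compound 1. The next compound, compound 3 `CCCCC(=O)NCC(=O)N(C)c1ccc(Cl)cc1C(=O)c1ccccc1Cl`, differs from compound 2 at a single place: butyl in place of isopropyl on a carbonyl carbon. In words, this is butyl in place of isopropyl on a carbonyl carbon. Going by the values given here, only one measured step bears on this change, a 2.1-fold higher number from compound 1 to compound 2 (0.32 log units; beyond the scatter), a modest step made at the same place. It swapped a ring for isopropyl, whereas neither isopropyl nor butyl has a ring. With so little evidence, no direction can be favoured with confidence, and a step smaller than that one is expected, probably within the scatter. The expected change is a 1.2-fold lower number from compound 2 to compound 3 (0.08 log units; within the scatter). For compound 3 the estimated value is 5 mg/kg, with an expected range of 2.5 mg/kg to 11 mg/kg.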

Compound 3, dose for half-maximal effect: 1.3 mg/kg
Compound 3: middle estimate off by 3.8-fold (0.59 log units), on the high side, outside the stated range (below it).
By their numbers in this assay, from the lowest: compound 3; then compound 1; then compound 2.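

In this assay this position on the carbonyl carbon responds not only to swapping a ring for a chain: isopropyl and butyl both lack a ring, yet replacing one with the other gives a 4.6-fold lower number from compound 2 to compound 3 (0.66 log units; beyond the scatter) and this step is larger than a 2.1-fold higher number from compound 1 to compound 2 (0.32 log units; beyond the scatter) in the opposite direction. Phenyl therefore does not set the lowest number among these groups, since butyl gives a 2.2-fold lower number from compound 1 to compound 3 (0.35 log units; beyond the scatter) and compound 3 has the lowest number of the three. A group without a ring can thus need either more or less compound than phenyl, depending on which chain it is.

Propyl or pentyl on the same carbonyl carbon would help show whether chain length alone tracks these numbers. The compounds shown cannot settle that, and no measurement at hand explains why butyl needs less compound than isopropyl.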